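This account rests on a few compounds, and the source may have more. Where it says the series, first, only, none or still open, it means among the compounds named here.

Measured so far:
compound 1, `CN1CCC(C(=O)N2Cc3c(NC(=O)Nc4cccc(F)c4)n[nH]c3C2(C)C)CC1`: 350 nM
compound 2, `CC(C)CC(=O)Nc1n[nH]c2c1CN(C(=O)C1CCN(C3CC3)CC1)C2(C)C`: 320 nM
compound 3, `CCN1CCC(C(=O)N2Cc3c(NC(=O)c4ccc(F)cc4)n[nH]c3C2(C)C)CC1`: 290 nM

Compound 1 gives the highest of the three numbers in a functional assay on A2780 cells (Homo sapiens) for antiproliferative activity, read by fluorescence, with a stated time of 72 h (on this read-out higher numbers stand for weaker inhibition and lower numbers for stronger inhibition), but its gap to compound 2 and to compound 3 lies within the scatter, so the three stand together. Compound 4, `CN1CCC(C(=O)N2Cc3c(NC(=O)c4ccc(F)c(F)c4)n[nH]c3C2(C)C)CC1`, is not yet measured. It differs from compound 1 in one place: 3,4-difluorophenyl in place of (3-fluorophenyl)amino on a carbonyl carbon. The (3-fluorophenyl)amino group leaves and the carbonyl carbon now carries the 3,4-difluorophenyl group. Going by the values given here, no measured pair isolates this change. Compound 3, which also carries an aryl group on its carbonyl carbon, sits with compound 1 and compound 2, so the step is expected to be small, with no direction beyond the scatter: a 1.2-fold lower number from compound 1 to compound 4 (0.07 log units; within the scatter). For compound 4 the expected value in this assay is 300 nM, range 120 nM to 750 nM.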

Compound 4, half-maximal inhibitory concentration: 100 nM
For compound 4 the middle estimate is 3.0-fold (0.48 log units) above the measured one, outside the stated range (below it).
By their numbers in this assay, from the lowest: compound 4; then compounds 3, 2 and 1 (each within the scatter of the next).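

In this assay the group on this carbonyl carbon matters: 3,4-difluorophenyl in place of (3-fluorophenyl)amino gives the only step beyond the scatter among the compounds shown (a 3.5-fold lower number from compound 1 to compound 4 (0.54 log units; beyond the scatter)). The change joins two alterations in one, since the hydrogen-bond donor of the leaving group goes and a second fluorine enters, while the heavy-atom count stays equal. No measurement at hand accounts for the step.

On these data alone, whether the loss of the amino link or the added fluorine carries the step stays open; 3-fluorophenyl or (3,4-difluorophenyl)amino on this carbonyl carbon would separate them. Also open, as far as these compounds go, is how a pyridyl ring or a carboxylic acid on the aryl group would read.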